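A few compounds are considered here, and "the series" means these few. Any claim that something is new, unique, unknown or untested is made for them only; others in the source may bear on it.

Measured compounds in a functional assay on DU-145 cells (Homo sapiens) for cytotoxicity, read by MTT assay; on this read-out higher numbers stand for weaker inhibition and lower numbers for stronger inhibition:
- compound 1 `c1ccc(-c2nnc(-c3c[nH]c4ccccc34)o2)cc1`: > 1000000 nM (a limit of the assay)
- compound 2 `c1ccc2c(-c3nnc(-c4ccncc4)o3)c[nH]c2c1`: 20400 nM
- compound 3 `c1cncc(-c2nnc(-c3c[nH]c4ccccc34)o2)c1`: 170000 nM

Compound 1 stands at the weak end of the three: in this assay compound 1 gives > 1000000 nM, which is a limit and not a number, so its true value is open upward. Going by the values given here, it is the one compound that sits at the limit of > 1000000 nM in this assay, at which 1 of the 3 values shown sits. Both replacements of its phenyl by a pyridinyl lowered the number: an at least 49-fold lower number from compound 1 to compound 2 (1.69 log units; beyond the scatter), and an at least 5.8-fold lower number from compound 1 to compound 3 (0.76 log units; beyond the scatter). Between the two pyridinyl isomers, an 8.3-fold higher number from compound 2 to compound 3 (0.92 log units; beyond the scatter).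

Compound 4 `COc1ccc(-c2nnc(-c3c[nH]c4ccccc34)o2)cc1` differs from compound 1 by methoxy in place of hydrogen on an aromatic carbon. Among the compounds with values here, no measured step bears directly on this change; the measured steps exchange the whole six-membered ring for a nitrogen-containing one, whereas here the phenyl is kept and a methoxy is added at the position para to a large group. Within the data shown here, the steps from compound 1 show only that the parent phenyl compound is the weakest of the set and that a ring change can move the number a lot; they give no direction for a methoxy. The expectation is therefore anchored on the limit of compound 1: an at least 1.6-fold lower number from compound 1 to compound 4 (0.22 log units; that floor lies within the scatter), with compound 4 estimated at 600000 nM, in the range 100000 nM to 3000000 nM, and a real chance that the assay again reports only a limit.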

Compound 4, half-maximal inhibitory concentration: > 1000000 nM
Compound 4 was reported as a limit; the forecaster's own chance of this, stated with the estimate: 55%; at least 1.6-fold (0.22 log units) between middle value and limit.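

Compound 1 and compound 4 both stand only as limits, so the step between them cannot be read: the limit of > 1000000 nM in this assay, at which 2 of the 4 values shown sit.

The compounds shown leave open whether methoxy in place of hydrogen on an aromatic carbon changes the number at all in this assay, and where the true values of compound 1 and compound 4 lie.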